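This account rests on a few compounds, and the source may have more. Where it says the series, first, only, none or still open, it means among the compounds named here.

Three compounds share one core and were tested in a functional assay on HCC827 cells (Homo sapiens) for inhibition, read by fluorescence, with a stated time of 72 h; a higher number here means a weaker inhibitor of growth, a lower number a stronger inhibitor of growth. Compound 2 `CCCCCCn1cnc2c(Nc3ccc(Cl)cc3)nc(N[C@H]3CC[C@H](N)CC3)nc21` gives 11700 nM in this assay. Compound 1 `CC(C)CCn1cnc2c(Nc3ccc(Cl)cc3)nc(N[C@H]3CC[C@H](N)CC3)nc21` differs from it only in the chain on the aromatic nitrogen; that difference is isopropyl in place of butyl on a saturated chain carbon, two bonds along the chain from an aromatic nitrogen and it produced a 1.1-fold lower number from compound 2 to compound 1 (0.06 log units; within the scatter), leaving compound 1 at 10200 nM. Compound 3 `CCCCCCn1cnc2c(Nc3cccc(Cl)c3)nc(N[C@H]3CC[C@H](N)CC3)nc21` keeps the chain of compound 2 and instead moves the chlorine on the phenyl ring; the cores of the two differ by 3-chlorophenyl in place of 4-chlorophenyl on a nitrogen on an aromatic ring, and this gave a 1.1-fold lower number from compound 2 to compound 3 (0.06 log units; within the scatter), so compound 3 sits at 10200 nM, level with compound 1 and compound 2 within the scatter.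

Compound 4 `CC(C)CCn1cnc2c(Nc3cccc(Cl)c3)nc(N[C@H]3CC[C@H](N)CC3)nc21` has not been measured. It is related to compound 3 by isopropyl in place of butyl on a saturated chain carbon, two bonds along the chain from an aromatic nitrogen, which is the same change, at the same place, that leads from compound 2 to compound 1. Since that change gave a 1.1-fold lower number from compound 2 to compound 1 (0.06 log units; within the scatter), a step of about the same size, within the scatter, is expected from compound 3 to compound 4: a 1.1-fold lower number from compound 3 to compound 4 (0.03 log units; within the scatter). In this assay compound 4 is therefore estimated at 9500 nM, between 5000 nM and 19000 nM.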

Compound 4, concentration for 50% growth inhibition: 10300 nM
The estimate for compound 4 lay 1.1-fold (0.04 log units) below the measured number; the range from low to high includes it.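

In this assay, isopropyl in place of butyl gives a 1.0-fold higher number from compound 3 to compound 4 (0.00 log units; within the scatter) and 3-chlorophenyl in place of 4-chlorophenyl gives a 1.0-fold higher number from compound 1 to compound 4 (0.00 log units; within the scatter), so these steps are too small to show whether a change with a clear effect on growth would carry from one core to another. The chain change reads alike on both cores: the same change on two cores in this assay, a 1.1-fold lower number (0.06 log units; within the scatter) from compound 2 to compound 1 and a 1.0-fold higher number (0.00 log units; within the scatter) from compound 3 to compound 4, 1.2-fold (0.06 log units) apart, within the scatter of two such steps. The move of the chlorine also reads alike on both cores: the same change on two cores in this assay, a 1.1-fold lower number (0.06 log units; within the scatter) from compound 2 to compound 3 and a 1.0-fold higher number (0.00 log units; within the scatter) from compound 1 to compound 4, 1.2-fold (0.06 log units) apart, within the scatter of two such steps.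

The compounds shown leave open whether another group, such as a chain ending in a hydroxyl or an amine, or a phenyl ring carrying a methoxy or a nitrile instead of chlorine, would shift the number beyond the scatter. They also leave open whether a change that does shift it would keep its size on a second core.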